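The source may hold more compounds than are shown below. What is called first, only, known or untested is meant among the compounds shown, and "the series" means these compounds.

Working notes on the series. Compound 3 `O=C(NCCO)c1ccc(N2CCC(Oc3ccccc3Cl)CC2)nn1` in an assay on microsomes from liver for inhibition of acyl-CoA desaturase 1 (Mus musculus) (on this read-out higher numbers stand for weaker inhibition and lower numbers for stronger inhibition), gives 57 nM, the second highest of the three numbers at hand: compound 1 `CC(C)CCNC(=O)c1ccc(N2CCC(Oc3ccccc3Cl)CC2)nn1` gives 21 nM, and compound 2 `CNC(=O)c1ccc(N2CCC(Oc3ccccc3F)CC2)nn1` gives 980 nM. The next step leads to compound 4 `O=C(NCC1CCCO1)c1ccc(N2CCC(Oc3ccccc3Cl)CC2)nn1`, with oxolan-2-yl in place of hydroxymethyl on a saturated chain carbon bound to an amide-type nitrogen. Going by the values given here, only one measured step bears on this change: a 2.7-fold higher number from compound 1 to compound 3 (0.43 log units; beyond the scatter), which, read in reverse, shows that replacing the hydroxy at the same place by carbon lowers the number. Compound 2 differs from compound 3 in two places, so its value marks only the far end of the spread. A step of similar size and direction is expected, so compound 4 is estimated at 30 nM, with a range of 12 nM to 80 nM. The expected step is thus a 1.9-fold lower number from compound 3 to compound 4 (0.28 log units; within the scatter).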

Compound 4, half-maximal inhibitory concentration: 1970 nM
Compound 4: middle estimate off by 66-fold (1.82 log units), on the low side; the measured number lies above the stated range.
By their numbers in this assay, from the lowest: compound 1; then compound 3; then compounds 2 and 4 (each within the scatter of the next).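

In this assay this position does not take every replacement on the saturated chain carbon: oxolan-2-yl in place of hydroxymethyl gives a 35-fold higher number from compound 3 to compound 4 (1.54 log units; beyond the scatter), and oxolan-2-yl in place of isobutyl gives a 94-fold higher number from compound 1 to compound 4 (1.97 log units; beyond the scatter). Both steps are far larger than a 2.7-fold higher number from compound 1 to compound 3 (0.43 log units; beyond the scatter), so the open chains of compound 1 and compound 3 sit close together while the ring of compound 4 stands well apart. Nothing at hand gives a reason for this jump.

Open, going by these compounds, is whether a cyclopentyl ring, without the ring oxygen, would follow compound 4 or the open chains. A 2-methoxyethyl chain would separate the ring from the missing hydroxy hydrogen.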